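Benzyloxy in Place of Hydrogen on the Shared Core

A few compounds are considered here, and "the series" means these few. Any claim that something is new, unique, unknown or untested is made for them only; others in the source may bear on it.

In a functional assay on HeLa cells (Homo sapiens) for inhibition, read by trypan blue exclusion, with a stated time of 72 h (on this read-out higher numbers stand for weaker inhibition of growth and lower numbers for stronger inhibition of growth), compound 1 `CC/C(=C(\c1ccccc1)c1ccc(NC(=O)C(C)C)cc1)c1ccccc1` gives > 30000 nM, which is a limit of the assay rather than a number. Compound 2 `CC/C(=C(/c1ccc(NC(=O)C(C)C)cc1)c1ccc(OC)cc1)c1ccccc1` likewise gives only a limit in this assay, > 30000 nM. Among the compounds with values here, the single measured step, a step that the two limits leave unreadable from compound 1 to compound 2, brings a methoxy in place of hydrogen on an aromatic carbon, and its size is not readable, because both of its ends rest at the limit of > 30000 nM in this assay, at which 2 of the 2 values shown sit. Compound 1 thus stands nowhere in particular on the numbers shown: it is known only to be weaker than the edge of the assay.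

Compound 3 `CC/C(=C(\c1ccccc1)c1ccc(NC(=O)C(C)C)cc1)c1ccc(OCc2ccccc2)cc1` differs from compound 1 by benzyloxy in place of hydrogen on an aromatic carbon. Within the data shown here, the only step that bears on this change is the one from compound 1 to compound 2, and since it is unreadable, it gives neither a direction nor a size to expect in this assay; no step beyond the scatter can be predicted from it. Compound 3 is therefore expected to sit near 30000 nM, most likely between 5000 nM and 100000 nM, with an estimated step of a number no higher from compound 1 to compound 3 (the limit leaves the size open) from compound 1.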

Compound 3, concentration for 50% growth inhibition: 10200 nM
Beside the measured number, compound 3's estimate is 2.9-fold (0.47 log units) above it; measured number inside the range.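

In this assay, benzyloxy in place of hydrogen on an aromatic carbon, para to a large group, gives an at least 2.9-fold lower number from compound 1 to compound 3 (0.46 log units; beyond the scatter). This is the only readable step among the compounds shown, since the step from compound 1 to compound 2 cannot be read, and it shows that a change at this place can bring the shared core to a measured number, with stronger inhibition of growth than compound 1 shows. Within the data shown here, the true size of the step stays unknown and compound 3 holds the only number in the set, with the other two values resting at the edge of the assay: the limit of > 30000 nM in this assay, at which 2 of the 3 values shown sit.

Going by these compounds, whether the entering oxygen or the entering aromatic ring carries this step stays open, and so does what a hydroxy, an ethoxy, an amine or a plain benzyl group would give on the same aromatic carbon. The compounds shown also leave open whether substituents on the ring of the benzyloxy group, such as a chlorine or a carboxylic acid, would move the number further, and whether the step holds with another amide on the shared core.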